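The compounds below may be only part of what the source reports. "The series", "measured", "known", "first", "only" and "open" are said of these compounds alone.

Of the compounds shown here, two have so far been measured in an assay for inhibition of MAP kinase-activated protein kinase 2 (Homo sapiens), read by Z'-LYTE, with a stated time of 1 h, tested at 10 uM; on this read-out lower numbers stand for less inhibition and higher numbers for more inhibition at the one concentration tested (going by the name of the read-out). Compound 1 `Nc1ncnc2c1ncn2[C@@H]1O[C@H](COC(=O)c2ccc[nH]2)[C@@H](O)[C@H]1O` gives 95%. Compound 2 `O=C(OC[C@H]1O[C@@H](n2cnc3c(=O)[nH]cnc32)[C@H](O)[C@@H]1O)c1cc[nH]c1` gives 89%, the lower of the two numbers, but by a margin that lies within the usual scatter of such measurements, so on this read-out the two cannot be told apart. Compound 3 `O=C(OC[C@H]1O[C@@H](n2cnc3c(=O)[nH]cnc32)[C@H](O)[C@@H]1O)c1ccc[nH]1` has not yet been measured in this assay. It keeps every atom of compound 2 and differs only in how they are joined: 1H-pyrrol-2-yl in place of 1H-pyrrol-3-yl on a carbonyl carbon. Going by the values given here, no measured pair shows what this change does on its own. Both measured compounds sit near the top of the scale, and compound 1, which also carries the 1H-pyrrol-2-yl group on its carbonyl carbon, gives 95%. The expected step is therefore a number 1 percentage points higher from compound 2 to compound 3 (within the scatter), nothing beyond the scatter. Compound 3 is estimated at 90%, with a likely range from 78% to 98%.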

Compound 3, a percentage reported as inhibition, at one concentration (the size of the read-out at that concentration, not a potency): 42%
Estimate against measurement, compound 3: 48 percentage points above, and the stated range ends above it.
By their numbers in this assay, from the lowest: compound 3; then compounds 2 and 1 (each within the scatter of the next).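

Swapping 1H-pyrrol-3-yl for 1H-pyrrol-2-yl on a carbonyl carbon adds and removes no atoms, yet it gives a number 47 percentage points lower from compound 2 to compound 3 (beyond the scatter). Going by these compounds alone, this position is therefore sensitive to how the pyrrole ring is joined, not only to which atoms are present, which the earlier compounds could not show. The 1H-pyrrol-2-yl group does not bring a low number in every compound shown, since compound 1 carries it too and gives 95%, so its outcome depends on the rest of the molecule.

No measurement here explains why the two ring attachments differ so sharply. From the compounds shown here alone, it also remains open whether a phenyl ring or a longer carbon chain on this carbonyl carbon would give a number close to that of compound 2 or of compound 3.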